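A few compounds are considered here, and "the series" means these few. Any claim that something is new, unique, unknown or untested is made for them only; others in the source may bear on it.

Measured compounds:
compound 1 `COc1cccc(CN2C(=O)CN(C(=O)c3cc4cc(OC)ccc4o3)C[C@@H]2CCc2ccccc2)c1` gives 4500 nM in an ADME assay on Vero cells (Chlorocebus sabaeus) for cytotoxicity, with a stated time of 7 days; on this read-out higher numbers stand for lower toxicity in this test and lower numbers for higher toxicity in this test.
compound 3 `COc1ccc2[nH]c(C(=O)N3CC(=O)N(Cc4ccc[nH]4)[C@@H](Cc4ccccc4)C3)cc2c1` gives 15200 nM in this assay.
compound 2 `COc1ccc2[nH]c(C(=O)N3CC(=O)N(Cc4ccccc4)[C@@H](CCc4ccccc4)C3)cc2c1` reaches only a limit, > 30000 nM in this assay.

Compound 2 thus sits at the upper end of what is shown, as a limit and not a number; it is the one compound that does so (the limit of > 30000 nM in this assay, at which 1 of the 3 values shown sits). Compound 4 `COc1ccc2[nH]c(C(=O)N3CC(=O)N(Cc4ccccc4)[C@@H](CN4CCC5(CCCC5)CC4)C3)cc2c1` differs from compound 2 in one place: a group of 10 heavy atoms (9 carbon, 1 nitrogen; one five-membered non-aromatic ring of carbon only, one six-membered non-aromatic ring with 1 hetero atom) in place of a group of 7 heavy atoms (7 carbon; one six-membered aromatic ring of carbon only), on a saturated chain carbon bound to a saturated ring carbon. Among the compounds with values here, no pair of measured compounds differs in a single place, so no measured step gives a size for this kind of change. The step from compound 2 to compound 4 is expected to be a loss beyond the scatter, as an at least 3.0-fold lower number from compound 2 to compound 4 (0.47 log units; beyond the scatter). Compound 4 is therefore estimated at 10000 nM, with a range from 3000 nM to 30000 nM.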

Compound 4, half-maximal cytotoxic concentration: 3600 nM
The estimate for compound 4 lay 2.8-fold (0.44 log units) above the measured number; measured number inside the range.
By their numbers in this assay, from the lowest: compounds 4 and 1 (each within the scatter of the next); then compound 3. At a limit, above all of these: compound 2.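

At this position, on a saturated chain carbon bound to a saturated ring carbon, replacing benzyl with the group of two non-aromatic rings gives in this assay an at least 8.3-fold lower number from compound 2 to compound 4 (0.92 log units; beyond the scatter). Within the data shown here, this is the only measured single-place step, and it shows that the group here bears on toxicity in this test. The size is a bound and not an exact figure, since compound 2 stands at a limit: the limit of > 30000 nM in this assay, at which 1 of the 4 values shown sits.

This one step does not separate the effect of the ring nitrogen from that of the larger group. As far as these compounds go, how a morpholine or a carboxylic acid at this position would read stays open.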